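The compounds below may be only part of what the source reports. "The series", "measured", "known", "first", "only" and "open" are said of these compounds alone.

Measured compounds:
compound 1 `O=C(c1ccccc1)c1sc(N2CCCC2)nc1-c1ccccc1`: 75.3%
compound 2 `O=C(c1ccccc1)c1sc(N2CCN(c3ccccc3)CC2)nc1-c1ccccc1`: 38.3%
compound 3 `COc1ccc(-c2nc(N3CCCCC3)sc2C(=O)c2ccccc2)cc1`: 62%

In an assay for inhibition of Polyunsaturated fatty acid 5-lipoxygenase (Homo sapiens), read by spectrophotometry, tested at 10 uM (a higher number here means more inhibition at the concentration tested (going by the name of the read-out), a lower number less inhibition), compound 2 stands lowest of the three numbers; compound 3 lies higher by a gap beyond the scatter, and compound 1 higher still, also beyond the scatter. Compound 4 `COc1ccc(-c2nc(N3CCN(c4ccccc4)CC3)sc2C(=O)c2ccccc2)cc1` has not yet been measured in this assay. It differs from compound 2 in one place: methoxy in place of hydrogen on an aromatic carbon. Going by the values given here, no pair of measured compounds shows this change alone, so its size cannot be read from the data; compound 3 carries the same methoxy group but differs from compound 2 in more than one place. For compound 4 a step of a number 3.7 percentage points higher from compound 2 to compound 4 (within the scatter) is expected, small and within the scatter. Compound 4 is estimated at 42%, between 25% and 60%.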

Compound 4, a percentage reported as inhibition, at one concentration (the size of the read-out at that concentration, not a potency): 53.1%
Compound 4: the middle estimate sits 11.1 percentage points below what was measured; the range from low to high includes it.
By their numbers in this assay, from the lowest: compound 2; then compounds 4 and 3 (each within the scatter of the next); then compound 1.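

In this assay, going by these compounds alone, the change from phenyl to 4-methoxyphenyl gives a number 14.8 percentage points higher from compound 2 to compound 4 (beyond the scatter) and is the first change seen alone in a pair of measured compounds. It shows that methoxy in place of hydrogen at this place, para to a large group, moves the inhibition by more than the scatter when the rest of compound 2 is kept. Nothing available explains this step.

From the compounds shown here alone, whether the step carries over to compounds with a different amine remains open. So does whether a hydroxyl, a fluorine or an ethoxy at the same place would give a similar step.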